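The compounds below may be only part of what the source reports. "The series", "measured", "known", "first", "only" and "open" are said of these compounds alone.

Measured compounds, with the response each reached:

Compound 1 `Cc1c(OCCCCOCOc2ccc(C(=O)O)cc2)ccc(C(=O)CC2CCCC2)c1O`: 46.9%
Compound 2 `CCCC(=O)c1ccc(OCCCCOc2ccc(C(=O)O)cc2C)c(C)c1O`: 40.5%
Compound 3 `Cc1ccc(C(=O)O)cc1OCCCCOc1ccc(C(=O)CC(C)C)c(O)c1C`: 29.4%

All three were run in an assay on HEK293 cells for positive allosteric modulation of metabotropic glutamate receptor 3 (Rattus norvegicus), read by thallium flux, with a stated time of 2.5 min; on this read-out higher numbers stand for larger maximal responses and lower numbers for smaller maximal responses. Compound 1 sits at the top of the three numbers, yet the gap to compound 2 lies within the usual scatter of repeated measurements, so those two cannot be told apart with confidence. Compound 3 lies beyond the scatter below compound 1, and that is the one gap among the three that counts as a real difference.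

Compound 4 `Cc1c(OCCCCOc2ccc(F)c(C(=O)O)c2)ccc(C(=O)CC2CCCC2)c1O` has not been measured yet. Compared with compound 1 it carries one change: 3-carboxy-4-fluorophenyl in place of (4-carboxyphenoxy)methyl on an oxygen on a saturated carbon. For the measured compounds named here, no pair of measured compounds shows this particular exchange, so there is no measured step to lean on; the three measured values simply show the range that this shared core has reached so far.

Against that background the change is expected to move the maximal response in this assay by a modest amount downward, at the edge of the scatter rather than far beyond it. This amounts to an expected step of a number 6.9 percentage points lower from compound 1 to compound 4 (within the scatter). Compound 4 is therefore estimated to reach about 40%, most likely between 26% and 54%.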

Compound 4, largest response reached (reported as percent of maximum), in percent of the reference or control that the assay uses: 98.4%
For compound 4 the middle estimate is 58.4 percentage points below the measured one; measured number outside the range, above it.
By their numbers in this assay, from the lowest: compound 3; then compounds 2 and 1 (each within the scatter of the next); then compound 4.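

In this assay, putting 3-carboxy-4-fluorophenyl in place of (4-carboxyphenoxy)methyl on an oxygen on a saturated carbon gives a number 51.5 percentage points higher from compound 1 to compound 4 (beyond the scatter), a large gain from one exchange. This shows that the group carried at this place can strongly change the maximal response while the rest of the molecule stays the same. The exchange brings in a fluorine and removes a linking oxygen together, and nothing at hand shows which of these matters or explains the gain.

As far as these compounds go, it remains open whether the fluorine is needed, which a 3-carboxyphenyl or 3-carboxy-4-chlorophenyl group at the same place would help to show. From the compounds shown here alone, it also remains open whether a tetrazole could stand in for the carboxylic acid on this ring.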